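A few compounds are considered here, and "the series" means these few. Any claim that something is new, unique, unknown or untested is made for them only; others in the source may bear on it.

Working notes on the series

Three compounds of this set carry a number in a functional assay on T47D cells (Homo sapiens) for inhibition, read by CCK-8 assay, with a stated time of 72 h, tested at 1 uM; on this read-out lower numbers stand for less inhibition of growth and higher numbers for more inhibition of growth at the one concentration tested. Compound 1 `CN(C)C(=O)c1cc2cnc(Nc3ccc(NC(=O)C4(C(=O)Nc5ccc(F)cc5)CC4)cc3F)nc2n1C1CCCC1` gives 6.3% in this assay. Compound 2 `CN(C)C(=O)c1cc2cnc(Nc3ccc(NC(=O)C4(C(=O)Nc5cccc(C(F)(F)F)c5)CC4)cc3)nc2n1C1CCCC1` gives 9.7% in this assay. Compound 3 `Cc1ccc(NC(=O)C2(C(=O)Nc3ccc(Nc4ncc5cc(C(=O)N(C)C)n(C6CCCC6)c5n4)cc3)CC2)cc1` gives 47.9% in this assay, the highest of the three numbers shown; the nearest of the others is compound 2, the furthest compound 1, both beyond the scatter. Among the measured compounds shown here, the one step between compounds differing in a single place is a number 38.2 percentage points higher from compound 2 to compound 3 (beyond the scatter), a change of 4-methylphenyl in place of 3-(trifluoromethyl)phenyl on an amide-type nitrogen. Compound 1 differs from the others in two places, so only its value can be set against theirs.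

Compound 4 `COc1ccc(NC(=O)C2(C(=O)Nc3ccc(Nc4ncc5cc(C(=O)N(C)C)n(C6CCCC6)c5n4)cc3)CC2)cc1` is not yet measured. It differs from compound 3 as methoxy in place of methyl on an aromatic carbon. For the measured compounds named here, the only measured step that bears on it is the step from compound 2 to compound 3, which also alters the aryl group on the same amide-type nitrogen and was large; but that step exchanged both substituent and position, whereas here only methyl gives way to methoxy on the same aromatic carbon. A smaller step, of uncertain direction, is therefore expected in this assay, most likely within the scatter: the expected step is a number 7.9 percentage points lower from compound 3 to compound 4 (within the scatter). Compound 4 is estimated to give 40% in this assay, in the range 15% to 62%.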

Compound 4, percent growth inhibition at one concentration: 76.4%
Compound 4: the middle estimate sits 36.4 percentage points below what was measured; measured number above the stated range.
By their numbers in this assay, from the lowest: compounds 1 and 2 (each within the scatter of the next); then compound 3; then compound 4.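

In this assay, methyl and methoxy on this aromatic carbon, para to a large group, are not interchangeable: the change gives a number 28.5 percentage points higher from compound 3 to compound 4 (beyond the scatter) with the rest of compound 3 left as it is. Unlike the earlier step, which altered substituent and position together, this one shows that the read-out responds to the substituent alone, with 4-methylphenyl giving way to 4-methoxyphenyl on the same amide-type nitrogen. Measured against the 3-(trifluoromethyl)phenyl group, the new aryl group gives a number 66.7 percentage points higher from compound 2 to compound 4 (beyond the scatter), and no evidence at hand accounts for the effect of the methoxy group.

The compounds shown leave open whether a hydroxy, ethoxy or dimethylamino group on this same aromatic carbon would read closer to methoxy or to methyl, and so whether the oxygen atom or the added heavy atom goes with the higher number. They also leave open how 4-fluorophenyl, the aryl group of compound 1, would read against 4-methoxyphenyl with the rest of compound 4 unchanged, since compound 1 differs from it in a second place as well.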